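The source may report more compounds than this note shows. Statements on the series, on what has been measured and on what is new or still open speak of the compounds shown alone.

Working notes on the series. Two compounds share the core of compound 1 `CN(C)C(=O)c1cc2cnc(Nc3ccc(C(=O)NCCCCN=C=S)cc3)nc2n1C1CCCC1` and have been measured in a functional assay on NCI-H1299 cells (Homo sapiens) for inhibition, read by CCK-8 assay, with a stated time of 72 h, tested at 1 uM; on this read-out lower numbers stand for a weaker effect and higher numbers for a stronger effect at the one concentration tested. In this assay compound 1 gives 55.2%, while compound 2 `CN(C)C(=O)c1cc2cnc(Nc3ccc(C(=O)NCCCN=C=S)cc3O)nc2n1C1CCCC1` gives 10.3%. Within the data shown here, compound 2 thus stands lowest of the two numbers, and its gap to compound 1 lies beyond the scatter; as compound 1 and compound 2 differ in more than one place, no single step between them is defined.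

The next compound, compound 3 `CN(C)C(=O)c1cc2cnc(Nc3ccc(C(=O)NCCCCN=C=S)cc3O)nc2n1C1CCCC1`, is not yet measured. It differs from compound 2 in one place: a group of 4 heavy atoms (2 carbon, 1 nitrogen, 1 sulfur; no ring) in place of a group of 3 heavy atoms (1 carbon, 1 nitrogen, 1 sulfur; no ring), on a saturated chain carbon, three bonds along the chain from an amide-type nitrogen. Compound 3 carries the longer chain of compound 1 together with the aryl hydroxyl of compound 2, so the pair of measured values brackets the question without settling it.

In this assay a moderate rise from compound 2 is expected, a number 19.7 percentage points higher from compound 2 to compound 3 (beyond the scatter), a step estimated to land beyond the scatter but short of compound 1. For compound 3 the expected value is 30%, with a range from 10% to 55%.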

Compound 3, a percentage reported as inhibition, at one concentration (the size of the read-out at that concentration, not a potency): 10.7%
Estimate against measurement, compound 3: 19.3 percentage points above; low and high end bracket the measured number.
By their numbers in this assay, from the lowest: compounds 2 and 3 (each within the scatter of the next); then compound 1.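

In this assay, the step at the saturated chain carbon, a number 0.4 percentage points higher from compound 2 to compound 3 (within the scatter), shows that with hydroxy on the aromatic carbon, the group of 4 heavy atoms and the group of 3 heavy atoms cannot be told apart at this one concentration. The single-place step for hydroxy in place of hydrogen on an aromatic carbon, a number 44.5 percentage points lower from compound 1 to compound 3 (beyond the scatter), is large and gives the series its first reading of that change with the chain held constant, so among these compounds the aromatic hydroxy, not the chain step, is the change that shifts the number. No measurement shown here explains this loss of effect.

The compounds shown leave open whether the chain step would also stay within the scatter with hydrogen on that aromatic carbon, since only the hydroxy-bearing pair reads that step. They also leave open where a methoxy group or a fluorine on that aromatic carbon would fall, and whether a longer chain would differ from the two chains compared here.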